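The source may hold more compounds than are shown below. What is called first, only, known or untested is meant among the compounds shown, and "the series" means these compounds.

Measured compounds:
- compound 1 `CCCCCCCCCCCCCCCCCCNC(=O)[C@@H]1CSC(c2cc(OC)c(OC)c(OC)c2)N1`: 820 nM
- compound 2 `CCCCCCCCCCCCCCCCCCNC(=O)[C@@H]1CSC(c2ccc(N(C)C)cc2)N1`: 1600 nM
- compound 3 `CCCCCCCCCCCCCCCCCCNC(=O)[C@H]1NC(c2cc(OC)c(OC)c(OC)c2)SC1(C)C`: > 20000 nM

In a functional assay on LNCaP cells (Homo sapiens) for antiproliferative activity, read by sulforhodamine B assay (on this read-out higher numbers stand for weaker inhibition and lower numbers for stronger inhibition), compound 1 gives 820 nM and compound 2 gives 1600 nM. The difference between them is 4-(dimethylamino)phenyl in place of 3,4,5-trimethoxyphenyl on a saturated ring carbon. The step is a 2.0-fold higher number from compound 1 to compound 2 (0.29 log units; within the scatter), so the two values cannot be told apart.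

Among the compounds with values here, compound 3 is reported in this assay only as a limit of the assay, > 20000 nM; it is the one value sitting at the limit of > 20000 nM in this assay, at which 1 of the 3 values shown sits. How the core of compound 3 differs from the core of compound 1 is not broken down here.

Compound 4 `CCCCCCCCCCCCCCCCCCNC(=O)[C@H]1NC(c2ccc(N(C)C)cc2)SC1(C)C` has not yet been measured in this assay. It differs from compound 3 by 4-(dimethylamino)phenyl in place of 3,4,5-trimethoxyphenyl on a saturated ring carbon. The surroundings are not identical to those in the first pair: here the place is also two ring bonds from the ring atom that bears two methyl groups, so this is the same kind of change, not the same change.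

For compound 4 the expected step is a step that the limit leaves unreadable from compound 3 to compound 4, resting on a 2.0-fold higher number from compound 1 to compound 2 (0.29 log units; within the scatter) and on compound 3 standing at > 20000 nM. Compound 4 is therefore estimated at 30000 nM, within 10000 nM to 100000 nM, and most likely again only a limit.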

Compound 4, half-maximal inhibitory concentration: > 20000 nM
Compound 4: only a limit was reported (the forecaster's own chance of this, stated with the estimate: 80%); the middle value does not contradict the limit.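

In this assay compound 3 and compound 4 both stand only at a limit, so the step between them cannot be read: the limit of > 20000 nM in this assay, at which 2 of the 4 values shown sit. On these data alone, it remains open whether 4-(dimethylamino)phenyl in place of 3,4,5-trimethoxyphenyl acts on the core of compound 3 as it does on the core of compound 1, and what values lie behind the two limits.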